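A few compounds are considered here, and "the series" means these few. Any claim that something is new, unique, unknown or untested is made for them only; others in the source may bear on it.

Measured in a functional assay on MCF7 cells (Homo sapiens) for cytotoxicity, read by MTT assay, with a stated time of 72 h; on this read-out higher numbers stand for weaker inhibition and lower numbers for stronger inhibition:
- Compound 1 `CN(C)CCCCCn1c2c(c3ccccc31)C(=O)c1c[n+]([O-])c3ccccc3c1C2=O`: 200 nM
- Compound 2 `O=C1c2c[n+]([O-])c3ccccc3c2C(=O)c2c1c1ccccc1n2Cc1cn(C[C@H](O)CO)nn1`: > 1000 nM (a limit)
- Compound 3 `CCCCN1CCN(CCCCn2c3c(c4ccccc42)C(=O)c2c[n+]([O-])c4ccccc4c2C3=O)CC1`: 6900 nM

Of the two actual numbers, compound 3 holds the higher. Compound 4 `CN(C)CCCCn1c2c(c3ccccc31)C(=O)c1c[n+]([O-])c3ccccc3c1C2=O` has dimethylamino in place of 4-butylpiperazin-1-yl on a saturated chain carbon, four bonds along the chain from an aromatic nitrogen. The closest evidence is the large 35-fold higher number from compound 1 to compound 3 (1.54 log units; beyond the scatter), which brought in that same 4-butylpiperazin-1-yl at that place. The an at least 5.0-fold higher number from compound 1 to compound 2 (0.69 log units; beyond the scatter) introduces a different group and bears less directly. A large step towards lower numbers, meaning stronger inhibition, is therefore expected in this assay. The estimated change is a 20-fold lower number from compound 3 to compound 4 (1.29 log units; beyond the scatter). For compound 4 the expected value is 350 nM, with an estimated range of 100 nM to 1500 nM.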

Compound 4, half-maximal inhibitory concentration: 220 nM
Compound 4: middle estimate off by 1.6-fold (0.20 log units), on the high side; the range from low to high includes it.
By their numbers in this assay, from the lowest: compounds 1 and 4 (each within the scatter of the next); then compound 3.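

In this assay, dimethylamino in place of 4-butylpiperazin-1-yl on the same chain gives a 31-fold lower number from compound 3 to compound 4 (1.50 log units; beyond the scatter), so the high number of compound 3 goes with that piperazine group and not with the chain alone. Dimethylamino in place of (dimethylamino)methyl at this place leaves no change beyond the scatter, with a 1.1-fold higher number from compound 1 to compound 4 (0.04 log units; within the scatter). There is also an at least 4.5-fold lower number from compound 2 to compound 4 (0.65 log units; beyond the scatter), which rests on a limit: the limit of > 1000 nM in this assay, at which 1 of the 4 values shown sits.

Going by these compounds, whether a morpholine or a piperazine without the butyl group would track dimethylamino or 4-butylpiperazin-1-yl stays open. So does the effect of a longer chain carrying dimethylamino.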